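Moving the fluorine around the sulfonyl-bound ring

A few compounds are considered here, and "the series" means these few. Any claim that something is new, unique, unknown or untested is made for them only; others in the source may bear on it.

Measured compounds:
Compound 1, `O=C(CCCc1cn(S(=O)(=O)c2ccccc2)c2ccccc12)NCCCn1ccnc1`, gives 13200 nM in an assay on isolated protein for activation of Insulin-degrading enzyme (Homo sapiens), read by fluorescence, with stated times of 10 min and 20 min; a lower number here means that less compound is needed, a higher number that more compound is needed for the effect.
Compound 2, `O=C(CCCc1cn(S(=O)(=O)c2ccccc2F)c2ccccc12)NCCCn1ccnc1`, gives 7940 nM in this assay.

Compound 2 stands at one end of these two numbers, yet the step of a 1.7-fold lower number from compound 1 to compound 2 (0.22 log units; within the scatter) lies within the scatter, so the two compounds cannot be told apart by this assay. Compound 3, `O=C(CCCc1cn(S(=O)(=O)c2cccc(F)c2)c2ccccc12)NCCCn1ccnc1`, differs from compound 2 by 3-fluorophenyl in place of 2-fluorophenyl on a sulfonyl sulfur: the fluorine stays, only its position on the ring bound to the sulfonyl sulfur shifts. Among the measured compounds shown here, the only measured step that bears on this is the introduction of that fluorine, a 1.7-fold lower number from compound 1 to compound 2 (0.22 log units; within the scatter), which itself did not rise above the scatter. Shifting the same atom is therefore expected to give, at most, a step of similar size in either direction, a 1.1-fold higher number from compound 2 to compound 3 (0.05 log units; within the scatter), and nothing beyond the scatter. Compound 3 is accordingly estimated at 9000 nM, with a range from 3000 nM to 27000 nM.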

Compound 3, half-maximal effective concentration: 10200 nM
Compound 3: middle estimate off by 1.1-fold (0.05 log units), on the low side, and the stated range covers the measured number.
By their numbers in this assay, from the lowest: compounds 2, 3 and 1 (each within the scatter of the next).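

In this assay, moving the fluorine on the ring bound to the sulfonyl sulfur gives a 1.3-fold higher number from compound 2 to compound 3 (0.11 log units; within the scatter) and so shows no effect of this shift that the assay can resolve. Set against the compound without fluorine, the new isomer gives a 1.3-fold lower number from compound 1 to compound 3 (0.11 log units; within the scatter) and so adds a second case in which a single fluorine on this ring leaves the result inside the scatter, with compound 1, compound 2 and compound 3 not separated from one another. Nothing measured alongside these numbers bears on how they should be interpreted.

From the compounds shown here alone, whether this ring tolerates larger changes remains open, such as a carboxylic acid or an amine in place of the fluorine. Also open, going by these compounds, is whether a longer chain on the amide would shift the result beyond the scatter.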